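A few compounds are considered here, and "the series" means these few. Any claim that something is new, unique, unknown or untested is made for them only; others in the source may bear on it.

Among the measured compounds shown here, in a functional assay (Homo sapiens) for inhibition, read by sulforhodamine B assay, with a stated time of 3 days (on this read-out higher numbers stand for weaker inhibition and lower numbers for stronger inhibition), three compounds on the shared core have numbers so far. Compound 1 `Clc1nc2c(NCc3ccccc3)nc(N3CCNCC3)nc2nc1N1CCCC1` gives 4000 nM, compound 2 `CN(C)c1nc2nc(N3CCNCC3)nc(N3CCCC3)c2nc1Cl` gives 5800 nM, and compound 3 `CN(C)c1nc(N2CCNCC2)nc2nc(NCc3ccccc3)c(Cl)nc12` gives 5900 nM. These three values lie within the scatter of one another, so compound 3 stands level with both. Compound 4 `CN(C)c1nc2nc(N3CCNCC3)nc(N(C)C)c2nc1Cl` departs from compound 3 in one place, with dimethylamino in place of benzylamino on an aromatic carbon. For the measured compounds named here, no measured pair shows this change alone. With compound 3 at 5900 nM and compound 2 at 5800 nM, no step beyond the scatter is expected in this assay. The expected step is a 1.0-fold higher number from compound 3 to compound 4 (0.01 log units; within the scatter). Compound 4 is estimated at 6000 nM, with an expected range of 2500 nM to 14000 nM.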

Compound 4, half-maximal inhibitory concentration: > 20000 nM
Compound 4: a limit, no number; the forecaster's own chance of this, stated with the estimate: 8%; middle value at least 3.3-fold (0.52 log units) from the limit.
By their numbers in this assay, from the lowest: compounds 1, 2 and 3 (each within the scatter of the next). At a limit, above all of these: compound 4.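

Compound 2 and compound 3, with pyrrolidin-1-yl and benzylamino on this aromatic carbon next to the ring nitrogen, lie within the scatter of each other in this assay, so they showed no dependence on the group here. Dimethylamino changes that, with an at least 3.3-fold higher number from compound 3 to compound 4 (0.53 log units; beyond the scatter) and an at least 3.4-fold higher number from compound 2 to compound 4 (0.53 log units; beyond the scatter), so both ring-bearing groups stand apart from this group without a ring. The value of compound 4 is a limit and not a number: the limit of > 20000 nM in this assay, at which 1 of the 4 values shown sits.

Going by these compounds, how far compound 4 actually lies stays open. So does how an open-chain amine such as diethylamino, or a ring amine such as morpholin-4-yl, would read at this position.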